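This account rests on a few compounds, and the source may have more. Where it says the series, first, only, none or still open, it means among the compounds named here.

Two compounds of this series have been run in an ADME assay on HaCaT cells (Homo sapiens) for cytotoxicity, read by MTT assay, with a stated time of 72 h; a higher number here means a weaker inhibitor, a lower number a stronger inhibitor. Compound 1 `COc1ccc(Nc2nnnn2-c2ccc(F)cc2)cc1` gives 101000 nM there. Compound 2 `COc1ccc(-n2nnnc2Nc2cccc(Cl)c2)cc1` gives 141000 nM in this assay, and the number for compound 1 lies within the usual scatter of that value, so the two cannot be told apart. Compound 3 `COc1ccc(-n2nnnc2Nc2ccc(Cl)cc2)cc1` is not yet measured. It differs from compound 2 in one place: 4-chlorophenyl in place of 3-chlorophenyl on a nitrogen on an aromatic ring. Among the compounds with values here, no measured pair in this set carries such a change, so nothing here supports a move beyond the scatter. The step expected in this assay is a 1.1-fold lower number from compound 2 to compound 3 (0.05 log units; within the scatter), none beyond the scatter. Compound 3 is therefore expected to give about 125000 nM in this assay, with a range from 60000 nM to 260000 nM.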

Compound 3, half-maximal inhibitory concentration: 143000 nM
Compound 3: middle estimate off by 1.1-fold (0.06 log units), on the low side; low and high end bracket the measured number.
By their numbers in this assay, from the lowest: compounds 1, 2 and 3 (each within the scatter of the next).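

In this assay, 4-chlorophenyl in place of 3-chlorophenyl on a nitrogen on an aromatic ring gives a 1.0-fold higher number from compound 2 to compound 3 (0.01 log units; within the scatter), the first one-place step available in the series. At this place, the two chlorophenyl groups cannot be told apart in this read-out. Nothing on hand bears on this result.

On these data alone, whether an amine or a carboxylic acid in place of the chlorine would shift the number beyond the scatter remains open. As far as these compounds go, whether the same holds for other groups on that phenyl ring also remains open.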